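The source may report more compounds than this note shows. Statements on the series, on what has been measured and on what is new or still open speak of the compounds shown alone.

Three compounds that share one core and differ in a single group have been measured in a functional assay on KBVIN cells (Homo sapiens) for antiproliferative activity, read by sulforhodamine B assay, with a stated time of 3 days; on this read-out lower numbers stand for an effect already at smaller amounts and higher numbers for an effect only at larger amounts of compound. Compound 1 `CCC1=C(O)c2c(oc(-c3ccc(SC)cc3)cc2=O)C(CC)(CC)C1=O` gives 1.38 uM, compound 2 `CCC1=C(O)c2c(oc(-c3cccc(C)c3)cc2=O)C(CC)(CC)C1=O` gives 3.69 uM, and compound 3 `CCC1=C(O)c2c(oc(-c3cccc(OC)c3)cc2=O)C(CC)(CC)C1=O` gives 1.22 uM. Compound 3 therefore sits level with one neighbour, a 1.1-fold lower number from compound 1 to compound 3 (0.05 log units; within the scatter), and clearly apart from the other, a 3.0-fold lower number from compound 2 to compound 3 (0.48 log units; beyond the scatter).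

The next molecule, compound 4 `CCC1=C(O)c2c(oc(-c3ccc(C)cc3C)cc2=O)C(CC)(CC)C1=O`, has 2,4-dimethylphenyl in place of 3-methoxyphenyl on an aromatic carbon, (2,4-dimethylphenyl in place of 3-methoxyphenyl on an aromatic carbon). The closest guide is the swap of methyl for methoxy, a 3.0-fold lower number from compound 2 to compound 3 (0.48 log units; beyond the scatter). Read in reverse, this step suggests that trading methoxy for methyl may raise the number by a modest amount. Among the measured compounds shown here, no measured compound carries 2,4-dimethylphenyl, so the effect of having two methyl groups is unknown, and the guide is only approximate. In this assay, a modest step toward a higher number is expected, a 2.1-fold higher number from compound 3 to compound 4 (0.33 log units; beyond the scatter). For compound 4 the estimated value is 2.6 uM, with an expected range from 1 uM to 6.5 uM.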

Compound 4, concentration for half-maximal effect: 8.52 uM
For compound 4 the middle estimate is 3.3-fold (0.52 log units) below the measured one; measured number outside the range, above it.
By their numbers in this assay, from the lowest: compounds 3 and 1 (each within the scatter of the next); then compound 2; then compound 4.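

In this assay, among the compounds shown here, compound 4 gives the highest number of the four, which shows that the group on this aromatic carbon, next to the ring oxygen, can push the number up much further than the earlier compounds suggested: a 7.0-fold higher number from compound 3 to compound 4 (0.84 log units; beyond the scatter), and a 6.2-fold higher number from compound 1 to compound 4 (0.79 log units; beyond the scatter). Two methyl groups also read worse than one, with a 2.3-fold higher number from compound 2 to compound 4 (0.36 log units; beyond the scatter), so among these four compounds the two rings bearing only methyl give the highest numbers. No measurement shown bears on the reason for this rise.

The compounds shown cannot say which of the two methyl groups carries the rise, a question that 2-methylphenyl and 4-methylphenyl would settle. On these data alone, how a phenyl ring bearing an amine or a carboxylic acid would read at this position also stays open.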